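This account rests on a few compounds, and the source may have more. Where it says the series, first, only, none or still open, it means among the compounds named here.

Measured compounds in a functional assay on HBL-100 cells (Homo sapiens) for inhibition, read by sulforhodamine B assay, with a stated time of 48 h; a lower number here means a stronger inhibitor of growth, a higher number a weaker inhibitor of growth:
- compound 1, `CC(=O)OC/C(=C\c1ccccc1)C(=O)c1ccccc1`, 17000 nM
- compound 2, `CC(=O)OC/C(=C\c1ccccc1Br)C(=O)c1ccccc1`, 22000 nM
- compound 3, `CC(=O)OC/C(=C\c1ccccc1[N+](=O)[O-])C(=O)c1ccccc1`, 26000 nM

Compound 3 carries the highest of the three numbers in this assay, but the distances are small: from compound 1 the step is a 1.5-fold higher number from compound 1 to compound 3 (0.18 log units; within the scatter), from compound 2 it is a 1.2-fold higher number from compound 2 to compound 3 (0.07 log units; within the scatter), and the step of a 1.3-fold higher number from compound 1 to compound 2 (0.11 log units; within the scatter) is likewise within the scatter. On these numbers compound 3 stands level with both neighbours; no ordering can be read from them.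

Compound 4, `CC(=O)OC/C(=C/c1ccccc1[N+](=O)[O-])C(=O)c1ccccc1`, keeps the atoms and bonds of compound 3 entirely. The change is the two compounds have the same atoms and bonds and differ only in configuration as drawn: 1 of 1 stereo elements differ; a double bond is drawn E in compound 3 and Z in compound 4. None of the three measured steps touches configuration: each of them swaps one substituent on an aromatic carbon for another, and all of them stay within the scatter. Within the data shown here, there is no measured step that bears on an E-to-Z change, so nothing supports an expectation of a shift in either direction beyond the scatter, and the uncertainty is wider than for the substituent swaps.

Compound 4 is therefore expected at 26000 nM in this assay, within a range of 9000 nM to 75000 nM, an estimated step of no change at the digits printed from compound 3 to compound 4 (within the scatter).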

Compound 4, concentration for 50% growth inhibition: > 100000 nM
Compound 4: no number, only a limit; the forecaster's own chance of this, stated with the estimate: 10%; at least 3.8-fold (0.58 log units) between middle value and limit.
By their numbers in this assay, from the lowest: compounds 1, 2 and 3 (each within the scatter of the next). At a limit, above all of these: compound 4.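

Configuration at the double bond is the first change in this series to register in this assay: the E-to-Z change gives an at least 3.8-fold higher number from compound 3 to compound 4 (0.58 log units; beyond the scatter) while the swaps among hydrogen, bromo and nitro on the aromatic carbon all stay within the scatter. The reading for compound 4 is a limit and not a number, so the step marks only a lower bound on the size of the change: the limit of > 100000 nM in this assay, at which 1 of the 4 values shown sits. The pair has no other difference, so this step can be assigned to the configuration alone: the fact that compounds 3 and 4 differ only in the configuration as drawn.

From the compounds shown here alone, whether the E-to-Z change carries the same weight with hydrogen or bromo in place of nitro stays open, as compounds 1 and 2 appear in the E form only. Also open, going by these compounds, is whether an amine or a carboxylic acid on that aromatic carbon would leave the E series as level as bromo and nitro do, and whether the Z form would then fall away in the same direction.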